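The source may hold more compounds than are shown below. What is called first, only, known or untested is meant among the compounds shown, and "the series" means these compounds.

Measured so far, in a functional assay on MES-SA/Dx5 cells (Homo sapiens) for inhibition, with a stated time of 72 h, in the presence of a further agent that is not named here; on this read-out lower numbers stand for stronger inhibition and higher numbers for weaker inhibition:
- compound 1 `Oc1c(CN2CCCC2)ccc2cccnc12` gives 2820 nM; 2820 nM (2 entries)
- compound 2 `Oc1c(CN2CCCC2)cc(Cl)c2cccnc12` gives 3210 nM; 3160 nM (2 entries)
- compound 3 `Oc1c(CN2CCCC2)cc(Br)c2cccnc12` gives 2690 nM

Within the data shown here, compound 3 stands at 2690 nM as its only single number in this assay, and two further entries for compound 3 carry no single number. Repeat entries agree closely, as seen for compound 2 in the several entries of compound 2 in this assay, 3210 nM; 3160 nM (2 entries) here. The three compounds lie within the usual scatter of one another, so no order among them can be read.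

Compound 4 `COCc1cc(CN2CCCC2)c(O)c2ncccc12` is still to be measured. Methoxymethyl replaces bromo on an aromatic carbon, para to a hydroxy group and meta to a (pyrrolidin-1-yl)methyl group, as counted in methoxymethyl in place of bromo on an aromatic carbon for this change. Among the measured compounds shown here, no step between measured compounds gives a direct measure of it. For the measured compounds named here, the only guide is the narrow spread of values, with compound 1 at 2820 nM; 2820 nM (2 entries) and compound 3 at 2690 nM within scatter of each other. No step beyond the scatter is therefore expected in this assay in either direction. The expected size of the change is a 1.1-fold higher number from compound 3 to compound 4 (0.05 log units; within the scatter) and no more than scatter. The estimate for compound 4 is 3000 nM with a range from 1400 nM to 6500 nM expected.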

Compound 4, half-maximal inhibitory concentration: 3550 nM
Estimate against measurement, compound 4: 1.2-fold (0.07 log units) below; the measured number falls inside the stated range.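

In this assay, methoxymethyl in place of bromo on the aromatic carbon para to a hydroxy group gives a 1.3-fold higher number from compound 3 to compound 4 (0.12 log units; within the scatter). Among these compounds, until now this position had carried only hydrogen, chloro or bromo, so compound 4 is the first case with a group of three heavy atoms there, one of them a hydrogen-bond acceptor, and that larger group still produces no step beyond the scatter. The series therefore reads the same across a single halogen and a short ether chain at this position, and the size of the step is of the same order as the spread seen between repeat entries, which for this read-out is illustrated by: the several entries of compound 2 in this assay, 3210 nM; 3160 nM (2 entries)

On these data alone, whether a carboxylic acid or an aminomethyl group on this carbon, or a longer chain such as 2-methoxyethoxymethyl, would move the number beyond the scatter remains open. All the compounds shown also keep the (pyrrolidin-1-yl)methyl group and the hydroxy group, so the effect of a morpholine in place of the pyrrolidine is equally unknown.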